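From cyclohexylamino to morpholin-4-yl on a carbonyl carbon

The source may hold more compounds than are shown below. What is called first, only, known or untested is meant among the compounds shown, and "the series" means these compounds.

Measured so far in a functional assay on HT-29 cells (Homo sapiens) for antiproliferative activity, read by MTT assay, with a stated time of 72 h (a lower number here means a stronger inhibitor, a higher number a weaker inhibitor), both values being limits:
Compound 1 `C=CC(=O)N(CC(=O)OC)c1nc(-c2ccccc2)cs1` gives > 30000 nM (a limit)
Compound 2 `C=CC(=O)N(CC(=O)NC1CCCCC1)c1nc(-c2ccccc2)cs1` gives > 30000 nM (a limit)

Compound 2 stands at > 30000 nM and this is a limit, not a number. Compound 1 stands at > 30000 nM and this too is a limit. The evidence so far is the limit of > 30000 nM in this assay, at which 2 of the 2 values shown sit, and it gives no number for either compound.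

Compound 3 `C=CC(=O)N(CC(=O)N1CCOCC1)c1nc(-c2ccccc2)cs1` has not yet been measured. Going by the values given here, the change from compound 2 to compound 3 is morpholin-4-yl in place of cyclohexylamino on a carbonyl carbon and it falls on the same carbonyl carbon as the one measured step. That step, a step that the two limits leave unreadable from compound 1 to compound 2, has no readable size, so no size or direction can be carried over from it. No step beyond the scatter is therefore expected in this assay and the reading will probably stay at the limit.

For compound 3 the estimated value is 30000 nM, with an expected range from 12000 nM to 60000 nM in this assay.

The expected step is a number no higher from compound 2 to compound 3 (the limit leaves the size open) on this estimate.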

Compound 3, half-maximal inhibitory concentration: 13300 nM
Estimate against measurement, compound 3: 2.3-fold (0.35 log units) above; the measured number falls inside the stated range.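

In this assay, the carbonyl carbon now carries a group that gives a readable number: compound 3, with morpholin-4-yl, gives 13300 nM, which shows that this position can move the result to a measured value. Morpholin-4-yl in place of cyclohexylamino gives an at least 2.2-fold lower number from compound 2 to compound 3 (0.35 log units; beyond the scatter), and morpholin-4-yl in place of methoxy gives an at least 2.2-fold lower number from compound 1 to compound 3 (0.35 log units; beyond the scatter); both sizes are minimums, so the true gaps are open at the upper end. The step between compound 1 and compound 2 still cannot be read, and both compounds remain limits rather than numbers: the limit of > 30000 nM in this assay, at which 2 of the 3 values shown sit.

The change from compound 2 to compound 3 alters several things at once, removing a hydrogen-bond donor and bringing in a ring oxygen as a hydrogen-bond acceptor, and the compounds shown do not separate these. Piperidin-1-yl on the same carbonyl carbon would keep the ring without the oxygen, while 4-methylpiperazin-1-yl would put a ring nitrogen in its place, so either could show whether the oxygen matters to the reading in this assay.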